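The compounds below may be only part of what the source reports. "The series", "measured", "known", "first", "only" and "open" are said of these compounds alone.

Measured so far:
- compound 1 `COc1cccc(Nc2cc(-c3ccccc3)oc(=O)c2)c1`: 0.55 uM
- compound 2 `COc1ccc(Nc2cc(C)oc(=O)c2)cc1`: only a limit, > 30 uM

In a functional assay on KBVIN cells (Homo sapiens) for cytotoxicity, read by MTT assay, with a stated time of 72 h (on this read-out higher numbers stand for an effect only at larger amounts of compound and lower numbers for an effect already at smaller amounts), compound 1 gives 0.55 uM. For compound 2 this assay reports no number, only the limit > 30 uM (the limit of > 30 uM in this assay, at which 1 of the 2 values shown sits). Compound 2 therefore stands at the limit of this assay, with no measured value of its own.

Compound 3 `COc1ccc(Nc2cc(C3CCCCC3)oc(=O)c2)cc1` differs from compound 2 in one place: cyclohexyl in place of methyl on an aromatic carbon. Going by the values given here, no measured pair covers this change. Among the compounds with values here, compound 1 differs from compound 2 in more than one place, so its two values show only that one compound has a measured number while the other sits at the limit.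

For the change from compound 2 to compound 3 a step of an at least 3.7-fold lower number from compound 2 to compound 3 (0.57 log units; beyond the scatter) toward lower concentrations is expected, beyond the scatter but with wide uncertainty. Compound 3 is estimated at 8 uM, within 1.5 uM to 40 uM.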

Compound 3, concentration for half-maximal effect: 4.39 uM
Beside the measured number, compound 3's estimate is 1.8-fold (0.26 log units) above it; the measured number falls inside the stated range.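

In this assay, cyclohexyl in place of methyl on an aromatic carbon next to the ring oxygen gives an at least 6.8-fold lower number from compound 2 to compound 3 (0.83 log units; beyond the scatter). Going by these compounds alone, this is the first change that can be read at a single place, and it shows that this position accepts cyclohexyl while the compound still gives a measured number. Compound 2 has only a limit, so the step gives a minimum size and not an exact one: the limit of > 30 uM in this assay, at which 1 of the 3 values shown sits.

On these data alone, whether the ring itself matters or only the added carbons remains open, as does the outcome with a longer chain such as n-hexyl, an amine or a carboxylic acid at this position. The phenyl of compound 1 cannot be set against the cyclohexyl of compound 3, as these two compounds differ in more than one place.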